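Fluoro added to the methyl-bearing carbon of compound 2

This account rests on a few compounds, and the source may have more. Where it says the series, first, only, none or still open, it means among the compounds named here.

Compound 2 `COc1ccc(F)c([C@H]2CC[C@H](COc3cccc([C@H](C4CC4)[C@@H](C)C(=O)O)c3)CC2)c1` gives 22 nM in a functional assay on cells for agonist activity at Free fatty acid receptor 1 (Homo sapiens), read by HTRF and inositol phosphate accumulation, with a stated time of 90 min; a higher number here means that more compound is needed for the effect, a lower number that less compound is needed. For the measured compounds named here, that is the lowest of the two numbers: compound 1 `COc1ccc(F)c([C@H]2CC[C@H](COc3cccc([C@@H](CC(=O)O)C4CC4)c3)CC2)c1` gives 199 nM in this assay, and the single one-place step between them, a 9.0-fold lower number from compound 1 to compound 2 (0.96 log units; beyond the scatter), is the only measured step available. Compound 3 `COc1ccc(F)c([C@H]2CC[C@H](COc3cccc([C@H](C4CC4)[C@H](F)C(=O)O)c3)CC2)c1` carries fluoro in place of hydrogen but lacks the methyl; in this assay compound 3 gives "not determined" (no result reported), so no number exists for it.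

Compound 4 `COc1ccc(F)c([C@H]2CC[C@H](COc3cccc([C@H](C4CC4)[C@@](C)(F)C(=O)O)c3)CC2)c1` differs from compound 2 in one place: fluoro in place of hydrogen on a saturated chain carbon bound to a carbonyl carbon and two saturated chain carbons.

Going by the values given here, no measured step bears directly on this change. The step of a 9.0-fold lower number from compound 1 to compound 2 (0.96 log units; beyond the scatter) concerns methyl in place of hydrogen, not fluoro, and compound 3, the one structure that would show fluoro alone, has no number. With the methyl retained in compound 4, the expectation is that its number stays near that of compound 2, with no step beyond the scatter but wide uncertainty in either direction. The estimate for compound 4 in this assay is therefore 40 nM, between 10 nM and 160 nM, which means an expected step of a 1.8-fold higher number from compound 2 to compound 4 (0.26 log units; within the scatter).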

Compound 4, half-maximal effective concentration: 3.1 nM
Beside the measured number, compound 4's estimate is 13-fold (1.11 log units) above it, outside the stated range (below it).
By their numbers in this assay, from the lowest: compound 4; then compound 2; then compound 1.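

In this assay, the saturated chain carbon bound to a carbonyl carbon and two saturated chain carbons takes fluoro on top of the methyl, and the number falls again, by a 7.1-fold lower number from compound 2 to compound 4 (0.85 log units; beyond the scatter). Methyl alone had already given a 9.0-fold lower number from compound 1 to compound 2 (0.96 log units; beyond the scatter), so the two changes at this carbon run the same way, and no compound shown goes against that. Read as one change, 1-carboxy-1-fluoroethyl in place of carboxymethyl gives a 64-fold lower number from compound 1 to compound 4 (1.81 log units; beyond the scatter), the largest step in the series, though nothing on hand accounts for it and the result stands as an observed number only.

Whether fluoro lowers the number without the methyl cannot be read, since compound 3 has no result reported, so the fluoro step is known only with the methyl present. Also open, on these data alone, is whether chloro, hydroxyl or a second methyl in place of the fluoro would keep the number near that of compound 4 (3.1 nM), or whether an ethyl in place of the methyl would do so with the fluoro retained.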